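The source may hold more compounds than are shown below. What is called first, only, known or untested is meant among the compounds shown, and "the series" means these compounds.

Three compounds on a shared core have values in an ADME assay on MT4 cells (Homo sapiens) for cytotoxicity, read by MTT assay; on this read-out higher numbers stand for lower toxicity in this test and lower numbers for higher toxicity in this test. Compound 1 `O=C(CSc1nnnn1-c1cccc2ccccc12)N/N=C/c1ccccc1Cl` gives 69700 nM. For compound 2 `O=C(CSc1nnnn1-c1cccc2ccccc12)N/N=C/c1ccccc1F` the assay reports only a limit, >= 118000 nM. For compound 3 `COc1ccc(/C=N/NC(=O)CSc2nnnn2-c2cccc3ccccc23)cc1` the assay again reports only a limit, > 298000 nM. Compound 3 therefore stands at the upper edge of the numbers shown, where its half-maximal cytotoxic concentration is not resolved into a number. Compound 4 `COc1ccc(/C=N/NC(=O)CSc2nnnn2-c2cccc3ccccc23)c(OC)c1` differs from compound 3 by methoxy in place of hydrogen on an aromatic carbon. Among the compounds with values here, no measured step adds a methoxy to an otherwise unchanged aryl group, so the guidance is indirect: an at least 4.2-fold higher number from compound 1 to compound 3 (0.63 log units; beyond the scatter), a step that the two limits leave unreadable from compound 2 to compound 3, and an at least 1.6-fold higher number from compound 1 to compound 2 (0.22 log units; that floor lies within the scatter). Each change toward the methoxy-bearing compound 3 raised the number or left it at a limit, the reading being bounded by the limit of > 298000 nM in this assay, at which 1 of the 3 values shown sits, and (the limit of >= 118000 nM in this assay, at which 1 of the 3 values shown sits). A second methoxy is therefore expected to give no step beyond the scatter, and compound 4 is expected to remain at the limit, the estimated step being a step that the limit leaves unreadable from compound 3 to compound 4. Compound 4 is thus estimated at 300000 nM, with a range from 150000 nM to 600000 nM.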

Compound 4, half-maximal cytotoxic concentration: 28300 nM
Estimate against measurement, compound 4: 11-fold (1.03 log units) above, outside the stated range (below it).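

In this assay, methoxy in place of hydrogen on an aromatic carbon ortho to a large group and meta to a methoxy group gives an at least 10-fold lower number from compound 3 to compound 4 (1.02 log units; beyond the scatter) and so shows that the high reading of the 4-methoxyphenyl compound does not carry over to 2,4-dimethoxyphenyl. The fall also reaches past both halogen-bearing compounds, with an at least 4.1-fold lower number from compound 2 to compound 4 (0.62 log units; beyond the scatter) and a 2.5-fold lower number from compound 1 to compound 4 (0.39 log units; beyond the scatter) on the same read-out, which leaves compound 4 with the lowest number of the four and so the highest toxicity in this test. The first of these steps is only a floor, since compound 3 is held at a limit: the limit of > 298000 nM in this assay, at which 1 of the 4 values shown sits.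

The compounds shown leave open whether the fall follows from a methoxy at this place alone or from the two methoxy groups together. They also leave open how an amine, a carboxylic acid or a longer chain such as ethoxy on this carbon would read.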